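The source may hold more compounds than are shown below. What is called first, only, known or untested is meant among the compounds shown, and "the series" means these compounds.

Measured so far in a functional assay on MCF7 cells (Homo sapiens) for cytotoxicity, read by MTT assay, with a stated time of 72 h, tested at 1 uM; a higher number here means more inhibition of growth at the concentration tested, a lower number less inhibition of growth:
compound 1, `N/C(=N\NC(=S)N1CCCCCC1)c1ccccn1`: 25.3%
compound 2, `N/C(=N\NC(=S)N1CCOCC1)c1ccccn1`: 14.7%
compound 3, `Cc1cccc(/C(N)=N/NC(=S)N2CCOCC2)n1`: 11.7%

Compound 1 stands highest of the three, and compound 2 sits below it by a gap that is beyond the scatter; the difference between the two cores is not broken down here. Compound 3 carries, relative to compound 2, the change (methyl in place of hydrogen on an aromatic carbon), and that change made the step of a number 3 percentage points lower from compound 2 to compound 3 (within the scatter), which lies within the scatter. Compound 2 and compound 3 therefore show no change that can be called real.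

Compound 4, `Cc1cccc(/C(N)=N/NC(=S)N2CCCCCC2)n1`, is not yet measured. For the measured compounds named here, it carries, relative to compound 1, the change (methyl in place of hydrogen on an aromatic carbon), the same change as the one made from compound 2 to compound 3. The expected step is a number 3.3 percentage points lower from compound 1 to compound 4 (within the scatter), a step of about the same size as the earlier one, because a number 3 percentage points lower from compound 2 to compound 3 (within the scatter) showed this change leaving the value essentially unchanged on the other core. Compound 4 is accordingly expected to give 22% in this assay, with a range from 10% to 34%.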

Compound 4, percent growth inhibition at one concentration: 6.3%
Estimate against measurement, compound 4: 15.7 percentage points above, outside the stated range (below it).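

In this assay, methyl in place of hydrogen on an aromatic carbon does not carry over from one core to the other with the same size of step: the same change on two cores in this assay, a number 3 percentage points lower (within the scatter) from compound 2 to compound 3 and a number 19 percentage points lower (beyond the scatter) from compound 1 to compound 4, 16 percentage points apart, beyond the scatter of two such steps

On the core of compound 1 the change gives a number 19 percentage points lower from compound 1 to compound 4 (beyond the scatter), so within this pair of cores a step read on one core does not predict the step on the other. The result does not show why the two cores differ, and two steps in one assay at one concentration set no rule for any other core in the series.

From the compounds shown here alone, it remains open whether the loss on the core of compound 1 is particular to methyl or would also follow from another group on the same aromatic carbon, next to the ring nitrogen. An ethyl, a methoxy or an amine at that place, read on both cores, would bear on this.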